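The source may report more compounds than this note shows. Statements on the series, on what has been measured and on what is new or still open speak of the compounds shown alone.

Working notes on the series. In a functional assay on SK-BR-3 cells (Homo sapiens) for antiproliferative activity, read by MTT assay, with a stated time of 72 h (a higher number here means a weaker inhibitor, a lower number a stronger inhibitor), compound 1 `CCN(CC)CCNc1cc(C)c2cc(NC(=O)c3ccc(Cl)c(Cl)c3)ccc2n1` gives 3710 nM, the lowest of the two numbers recorded; the nearest is compound 2 `CCN1CCN(c2cc(C)c3cc(NC(=O)c4cccnc4)ccc3n2)CC1`, which gives 10600 nM. Compound 3 `CCN1CCN(c2cc(C)c3cc(NC(=O)c4ccccc4Cl)ccc3n2)CC1` is reported only as a limit, > 50000 nM, and sits at the limit of > 50000 nM in this assay, at which 1 of the 3 values shown sits. Among the measured compounds shown here, the one step measured so far, an at least 4.7-fold higher number from compound 2 to compound 3 (0.67 log units; beyond the scatter), changes the group on the carbonyl carbon and so does not touch the part of the core altered here. Compound 4 `CCN(CC)c1cc(C)c2cc(NC(=O)c3ccc(Cl)c(Cl)c3)ccc2n1` differs from compound 1 by diethylamino in place of (2-(diethylamino)ethyl)amino on an aromatic carbon. For the measured compounds named here, no measured step covers this change, so the expectation rests on compound 1 alone and is taken as no step beyond the scatter, with a lean toward a higher number. Compound 4 is estimated at 6000 nM, within 2000 nM to 20000 nM, i.e. an expected 1.6-fold higher number from compound 1 to compound 4 (0.21 log units; within the scatter).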

Compound 4, half-maximal inhibitory concentration: 41200 nM
For compound 4 the middle estimate is 6.9-fold (0.84 log units) below the measured one; measured number outside the range, above it.
By their numbers in this assay, from the lowest: compound 1; then compound 2; then compound 4. At a limit, above all of these: compound 3.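

Replacing (2-(diethylamino)ethyl)amino with diethylamino on the aromatic carbon next to the ring nitrogen gives an 11-fold higher number from compound 1 to compound 4 (1.05 log units; beyond the scatter), so this position is not indifferent to the group it carries. Among the compounds shown here, the group on the carbonyl carbon is the same in this pair, whereas the earlier step changed only that group. Compound 4 still gives a number, and compound 3 alone is reported as a limit: the limit of > 50000 nM in this assay, at which 1 of the 4 values shown sits.

The pair cannot separate chain length from the hydrogen-bond donor. A longer chain such as (3-(diethylamino)propyl)amino, or ethylamino, would bear on that.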